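The source may report more compounds than this note shows. Statements on the series, on what has been measured and on what is new or still open speak of the compounds shown alone.

Among the measured compounds shown here, compound 1, `Cc1nc(C)c(C(=O)Oc2ccc(/C=C/C(=O)O)cc2O)nc1C`, stands at the top of the three numbers so far: in a functional assay on EA.hy 926 cells (Homo sapiens) for cytotoxicity, read by MTT assay, with stated times of 24 h and 12 h, tested at 25 uM (a lower number here means a weaker effect, a higher number a stronger effect of the compound at the concentration tested), compound 1 gives 271%. For the measured compounds named here, compound 3, `CCOC(=O)/C=C/c1ccc(OC(=O)c2nc(C)c(C)nc2C)c(O)c1`, gives 207% in this assay, and the step of a number 64 percentage points lower from compound 1 to compound 3 (beyond the scatter) is the only one-point change measured; it puts ethyl in place of hydrogen on an oxygen next to a carbonyl group. Compound 2, `Cc1nc(C)c(C(=O)Oc2ccccc2/C=C/C(=O)O)nc1C`, gives 61.8%, the lowest of the three, but it differs from compound 1 in more than one place, so the two values are only compared, not traced to a single change.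

Compound 4, `COc1cc(/C=C/C(=O)O)ccc1OC(=O)c1nc(C)c(C)nc1C`, differs from compound 1 by methyl in place of hydrogen on an oxygen on an aromatic ring. Going by the values given here, no measured step touches this oxygen on the aromatic ring; the one measured step, from hydrogen to an alkyl on the other oxygen, was large and downward. Among the compounds with values here, with no direct precedent, the expectation is a downward step in this assay, smaller than that one and uncertain: the expected step is a number 61 percentage points lower from compound 1 to compound 4 (beyond the scatter). Compound 4 is thus expected to give about 210%, somewhere between 110% and 300%.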

Compound 4, a percentage reported as activity, at one concentration (the size of the read-out at that concentration, not a potency): 40.3%
Estimate against measurement, compound 4: 169.7 percentage points above; the measured number lies below the stated range.
By their numbers in this assay, from the lowest: compound 4; then compound 2; then compound 3; then compound 1.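

Hydroxy to methoxy on this oxygen on an aromatic ring is the larger of the two one-point changes in the series: in this assay the step is a number 230.7 percentage points lower from compound 1 to compound 4 (beyond the scatter), while ethyl in place of hydrogen on the other oxygen gives a number 64 percentage points lower from compound 1 to compound 3 (beyond the scatter) in the same assay. A single added heavy atom at this position therefore moves the read-out further than the two-carbon ethyl change does at the other oxygen, so within these compounds the read-out depends more on this oxygen. No measurement at hand bears on why the read-out falls so far at this position.

Open, from the compounds shown here alone, is whether a longer chain on this oxygen, or an amine in place of the hydroxy, would follow methyl or stay nearer compound 1. Also open, going by these compounds, is whether methyl here gives a step of similar size when the ethyl ester of compound 3 is present.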